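Diphenylmethyl sulfoxide series: heteroaryl swap on the chain carbon

The compounds below may be only part of what the source reports. "The series", "measured", "known", "first", "only" and "open" are said of these compounds alone.

Measured compounds:
compound 1 `COC1NN=C(C[S+]([O-])C(c2ccccc2)c2ccccc2)S1` gives 108000 nM
compound 2 `[O-][S+](Cc1nc(C(F)(F)F)no1)C(c1ccccc1)c1ccccc1` gives 43700 nM

For the measured compounds named here, in an assay on HEK293 cells for inhibition of sodium-dependent dopamine transporter (Homo sapiens), read by scintillation counting, with stated times of 5 min and 1 min (a higher number here means a weaker inhibitor, a lower number a stronger inhibitor), compound 1 gives 108000 nM, the highest number of the two measured so far. Compound 2 gives 43700 nM, a lower number by a margin beyond the usual scatter, so of the two, compound 2 is the stronger inhibitor, though both sit at the weak end of the range.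

Compound 3 `[O-][S+](Cc1cc(Br)cs1)C(c1ccccc1)c1ccccc1` keeps the shared core of compound 1 and alters only the group on the saturated chain carbon bound to a sulfur: a group of 6 heavy atoms (4 carbon, 1 sulfur, 1 bromine; one five-membered aromatic ring with 1 hetero atom) in place of a group of 7 heavy atoms (3 carbon, 2 nitrogen, 1 oxygen, 1 sulfur; one five-membered non-aromatic ring with 3 hetero atoms), on a saturated chain carbon bound to a sulfur. Going by the values given here, no measured pair isolates a change of this kind, so nothing in the data fixes its size or direction. Given that compound 2, with a different five-membered heteroaryl ring at the same place, gives 43700 nM, a modest move towards a lower number seems plausible, though a result within the scatter of compound 1 cannot be ruled out.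

For compound 3 the expected step is a 3.6-fold lower number from compound 1 to compound 3 (0.56 log units; beyond the scatter). Compound 3 is therefore estimated at 30000 nM, with a range from 7000 nM to 130000 nM.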

Compound 3, half-maximal inhibitory concentration: 13700 nM
Compound 3: the middle estimate sits 2.2-fold (0.34 log units) above what was measured, and the stated range covers the measured number.
By their numbers in this assay, from the lowest: compound 3; then compound 2; then compound 1.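

Replacing the five-membered non-aromatic ring with 3 hetero atoms by 4-bromothiophen-2-yl on the saturated chain carbon bound to a sulfur gives a 7.9-fold lower number from compound 1 to compound 3 (0.90 log units; beyond the scatter) in this assay, which shows that the number responds to the group at this place by more than the scatter. In the same read-out, compound 2 gives 43700 nM and compound 3 gives 13700 nM, so the lowest number of the three comes from the ring with a single hetero atom and a bromine, not from either ring carrying nitrogen. No available measurement bears on the reason for this step.

The compounds shown do not separate the contribution of the bromine from that of the thiophene ring, a question that an unsubstituted thiophen-2-yl group or a 4-chlorothiophen-2-yl group at the same place would address. Also open, going by these compounds, is how an amine, a carboxylic acid or a longer chain on this saturated chain carbon would read in this assay, and whether any group here can move the number far from the weak end of the range.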